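The source may hold more compounds than are shown below. What is called first, only, known or untested is meant among the compounds shown, and "the series" means these compounds.

Compound 1 `c1ccc(-c2noc(-c3cc4ccccc4[nH]3)n2)cc1`, compound 2 `Clc1ccc(-c2noc(-c3cc4ccccc4[nH]3)n2)cc1` and compound 3 `O=[N+]([O-])c1ccc2[nH]c(-c3nc(-c4ccc(Cl)cc4)no3)cc2c1` share one core and were all tested in a functional assay on MCF7 cells (Homo sapiens) for antiproliferative activity, read by WST assay, with a stated time of 72 h; a lower number here means a stronger inhibitor, a higher number a weaker inhibitor. In this assay compound 1 gives 45700 nM. In this assay compound 2 gives only a limit, > 50000 nM. In this assay compound 3 likewise gives only a limit, > 50000 nM. The two measured steps are an at least 1.0-fold higher number from compound 1 to compound 2 (0.03 log units; that floor lies within the scatter) and a step that the two limits leave unreadable from compound 2 to compound 3, and two of the three values sit at the limit of > 50000 nM in this assay, at which 2 of the 3 values shown sit. Compound 4 `COc1ccc(-c2noc(-c3cc4ccccc4[nH]3)n2)cc1` differs from compound 2 by methoxy in place of chloro on an aromatic carbon. Neither measured step involves a methoxy group, and no step beyond the scatter has been seen in this set. The step from compound 2 to compound 4 is therefore expected to be a step that the limit leaves unreadable from compound 2 to compound 4. Compound 4 is estimated at 60000 nM, within a range from 25000 nM to 150000 nM.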

Compound 4, half-maximal inhibitory concentration: > 50000 nM
Compound 4 was reported as a limit; the forecaster's own chance of this, stated with the estimate: 60%; the middle value is on the limit's open side.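

In this assay compound 4 also gives only a limit, > 50000 nM, so methoxy, like chloro, yields no measured number at this place, para to a large group. Methoxy in place of hydrogen gives an at least 1.0-fold higher number from compound 1 to compound 4 (0.03 log units; that floor lies within the scatter), and the step from chloro to methoxy cannot be read. Values now gather at one limit: the limit of > 50000 nM in this assay, at which 3 of the 4 values shown sit.

The compounds shown leave open whether any group at this place, such as an amine or a carboxylic acid, would give a number clearly lower than that limit.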